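From a Chlorophenyl to a Nitrophenyl Triazole Substituent

The compounds below may be only part of what the source reports. "The series", "measured", "known", "first", "only" and "open" are said of these compounds alone.

Compound 3 `Nc1nn(Cc2cn(-c3cccc(Cl)c3)nn2)c2nc(-c3ccccc3)cc(C(F)(F)F)c12` gives 32.4 ug/mL in a functional assay on U-937 cells (Homo sapiens) for cytotoxicity, read by MTT assay, with a stated time of 24 h (on this read-out higher numbers stand for weaker inhibition and lower numbers for stronger inhibition), the second highest of the three numbers shown. Compound 1 `CCCCCCCCCCn1cc(Cn2nc(N)c3c(C(F)(F)F)cc(-c4ccccc4)nc32)nn1` gives 27.1 ug/mL and compound 2 `Nc1nn(Cc2cn(-c3ccc(F)c(Cl)c3)nn2)c2nc(-c3ccccc3)cc(C(F)(F)F)c12` gives 99.1 ug/mL in this assay. The step of a 1.2-fold higher number from compound 1 to compound 3 (0.08 log units; within the scatter) and the step of a 3.7-fold higher number from compound 1 to compound 2 (0.56 log units; beyond the scatter) show that an aryl group on this nitrogen leaves the number close to or above that of compound 1, and a 3.1-fold lower number from compound 2 to compound 3 (0.49 log units; beyond the scatter) shows that one substituent on that aryl ring moves it modestly. Compound 4 `Nc1nn(Cc2cn(-c3ccc([N+](=O)[O-])cc3)nn2)c2nc(-c3ccccc3)cc(C(F)(F)F)c12` carries the change (4-nitrophenyl in place of 3-chlorophenyl on an aromatic nitrogen). For the measured compounds named here, no measured step swaps one aryl substituent for another of a different kind, so only a small step is expected, a 1.2-fold higher number from compound 3 to compound 4 (0.09 log units; within the scatter). Compound 4 is estimated at 40 ug/mL, with a range from 15 ug/mL to 110 ug/mL.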

Compound 4, half-maximal inhibitory concentration: 98.8 ug/mL
For compound 4 the middle estimate is 2.5-fold (0.39 log units) below the measured one, within the range that was stated.
By their numbers in this assay, from the lowest: compounds 1 and 3 (each within the scatter of the next); then compounds 4 and 2 (each within the scatter of the next).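

In this assay, a change of aryl group on this aromatic nitrogen again shifts the number, with a 3.0-fold higher number from compound 3 to compound 4 (0.48 log units; beyond the scatter) for 4-nitrophenyl in place of 3-chlorophenyl. Compound 4 lies within the scatter of the 3-chloro-4-fluorophenyl analogue, with a 1.0-fold lower number from compound 2 to compound 4 (0.00 log units; within the scatter) and stands apart from the decyl compound, with a 3.6-fold higher number from compound 1 to compound 4 (0.56 log units; beyond the scatter) so of the three aryl groups only 3-chlorophenyl stays within the scatter of decyl. No measurement shown here accounts for these differences.

The step changes both the substituent and its ring position, so 4-chlorophenyl or 3-nitrophenyl would be needed to separate the two. Going by these compounds, how an amine or a carboxylic acid on this ring would read remains open.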